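The source may hold more compounds than are shown below. What is called first, only, known or untested is meant among the compounds shown, and "the series" means these compounds.

Of the compounds shown here, three have so far been tested in a functional assay on CFPAC-1 cells (Homo sapiens) for antiproliferative activity, read by MTT assay, with a stated time of 72 h; on this read-out lower numbers stand for stronger inhibition and higher numbers for weaker inhibition. Compound 1 `COc1ccc(-c2cn(C/C=C3\OC(=O)C(OCc4ccccc4)=C3OCc3ccccc3)nn2)cc1` reaches only a limit of the assay, > 100000 nM. Compound 3 `Cc1ccc(-c2cn(C/C=C3\OC(=O)C(OCc4ccccc4)=C3OCc3ccccc3)nn2)cc1` likewise ends at a limit, > 100000 nM. The step from compound 1 to compound 3, a step that the two limits leave unreadable from compound 1 to compound 3, therefore cannot be read. Among the compounds with values here, compound 2 `O=C1O[C@H]([C@@H](O)Cn2cc(-c3cccc(O)c3)nn2)C(OCc2ccccc2)=C1OCc1ccccc1` is the one compound with a measured number: in this assay compound 2 gives 54100 nM, the only real value among the three, the other two sitting at the limit of > 100000 nM in this assay, at which 2 of the 3 values shown sit.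

Compound 4 `O=C1O[C@H]([C@@H](O)Cn2cc(CCO)nn2)C(OCc2ccccc2)=C1OCc1ccccc1` has not yet been measured. It differs from compound 2 in one place: 2-hydroxyethyl in place of 3-hydroxyphenyl on an aromatic carbon. Within the data shown here, no measured step touches this change; the only measured step, between compound 1 and compound 3, concerns a different position and is unreadable in any case. Compound 2 itself lies far from strong inhibition, so a weaker compound would soon meet the assay limit. With nothing pointing in either direction, compound 4 is expected to come out at 80000 nM, within a range from 30000 nM to 200000 nM. This amounts to an expected step of a 1.5-fold higher number from compound 2 to compound 4 (0.17 log units; within the scatter), which need not exceed the usual scatter.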

Compound 4, half-maximal inhibitory concentration: > 100000 nM
Compound 4 was reported as a limit; the forecaster's own chance of this, stated with the estimate: 50%; at least 1.2-fold (0.09 log units) between middle value and limit.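

Within the data shown here, the change from 3-hydroxyphenyl to 2-hydroxyethyl on the aromatic carbon of the triazole gives the first step at this position that can be read, though only in part: in this assay it is an at least 1.8-fold higher number from compound 2 to compound 4 (0.26 log units; that floor lies within the scatter). The value of compound 4, > 100000 nM, is a limit of the assay and not a number. The step is therefore only a floor, and since that floor does not clear the scatter, the swap of the ring for this short chain may have cost activity, but the result does not establish it, and compound 4 simply joins the other compounds at the limit: the limit of > 100000 nM in this assay, at which 3 of the 4 values shown sit.

The compounds shown leave open whether the aromatic ring or its hydroxyl is what goes with the measurable value of compound 2, a question that a plain phenyl group in the same place would address. They also leave open whether any other group here, such as an aminomethyl group, a carboxylic acid or a longer chain like 4-hydroxybutyl, would give a real number in this assay.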